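Removing the hydroxy group from a diterpenoid glycoside

The compounds below may be only part of what the source reports. "The series", "measured", "known", "first", "only" and "open" are said of these compounds alone.

Two glycosides have been measured in a functional assay on BV-2 cells (Mus musculus) for inhibition, read by Griess assay, with a stated time of 24 h; a higher number here means a weaker inhibitor, a lower number a stronger inhibitor. Compound 1 `C[C@]12CCC[C@](C)(C(=O)O[C@@H]3O[C@H](CO)[C@@H](O)[C@H](O)[C@H]3O)[C@@H]1CC=C(CO)[C@@H]2CCC1=CCOC1=O` gives 93200 nM in this assay. Compound 2 `C=C1C[C@H](O)[C@@H]2[C@](C)(CCC[C@]2(C)C(=O)O[C@@H]2O[C@H](CO)[C@@H](O)[C@H](O)[C@H]2O)[C@H]1CCC1=CCOC1=O` gives 35700 nM in this assay, the lower of the two numbers; the gap to compound 1 lies beyond the usual scatter, so compound 2 is the stronger inhibitor of the pair. For the measured compounds named here, no two measured compounds differ in only one place, so no single structural step has yet been quantified.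

Compound 3 `C=C1CC[C@@H]2[C@](C)(CCC[C@]2(C)C(=O)O[C@@H]2O[C@H](CO)[C@@H](O)[C@H](O)[C@H]2O)[C@H]1CCC1=CCOC1=O` has not been measured. It differs from compound 2 in one place: hydrogen in place of hydroxy on a saturated ring carbon. Going by the values given here, with no measured step for this kind of change, the expectation rests on compound 2 alone, whose value in this assay is 35700 nM. The step is expected to be small, perhaps not beyond the scatter, with a modest lean toward a weaker inhibitor: a 1.3-fold higher number from compound 2 to compound 3 (0.10 log units; within the scatter). Compound 3 is estimated at 45000 nM, within a range from 15000 nM to 130000 nM.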

Compound 3, half-maximal inhibitory concentration: 65800 nM
The estimate for compound 3 lay 1.5-fold (0.17 log units) below the measured number; measured number inside the range.
By their numbers in this assay, from the lowest: compounds 2, 3 and 1 (each within the scatter of the next, the first and the last beyond it).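

In this assay, for the compounds shown here, hydrogen in place of hydroxy on a saturated ring carbon gives the first quantified single-place step: a 1.8-fold higher number from compound 2 to compound 3 (0.27 log units; within the scatter). At this position, next to the ring atom that bears a fused ring, the hydroxy group is therefore not shown to be needed, since compound 3 lacks it and cannot be told apart from compound 2 in this read-out. Nothing available here accounts for the size of this step.

Going by these compounds, whether a different group on this saturated ring carbon, such as an amine, a methoxy group or a carboxylic acid, would produce a step beyond the scatter remains open. Also open, on these data alone, is how a hydroxy group with the opposite configuration at this carbon would compare with compound 2.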